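Swapping a fluoroethyl chain for cyclopentyl on a shared core

The source may report more compounds than this note shows. Statements on the series, on what has been measured and on what is new or still open speak of the compounds shown alone.

Compound 1, `COC/C(=C(/c1ccc(/C=C/C(=O)O)cc1)c1ccc2[nH]ncc2c1)c1ccccc1`, gives 88 nM.
Compound 2, `O=C(O)/C=C/c1ccc(/C(=C(/CCF)c2ccccc2)c2ccc3[nH]ncc3c2)cc1`, gives 2.1 nM.
Compound 3, `O=C(O)/C=C/c1ccc(/C(=C(\c2ccccc2)C(F)F)c2ccc3[nH]ncc3c2)cc1`, gives 14 nM.

These numbers come from a functional assay on MCF7 cells (Homo sapiens) for cytotoxicity, read by CellTiter-Glo, with a stated time of 5 days; a lower number here means a stronger inhibitor, a higher number a weaker inhibitor. Compound 2 stands lowest of the three: the nearest is compound 3, reached by a 6.7-fold higher number from compound 2 to compound 3 (0.82 log units; beyond the scatter), and the furthest is compound 1, from which compound 2 is reached by a 42-fold lower number from compound 1 to compound 2 (1.62 log units; beyond the scatter). Compound 4, `O=C(O)/C=C/c1ccc(/C(=C(\c2ccccc2)C2CCCC2)c2ccc3[nH]ncc3c2)cc1`, is not yet measured. Going by the values given here, its one change from compound 2 is cyclopentyl in place of 2-fluoroethyl on a double-bonded chain carbon bound to an aromatic carbon and a double-bonded chain carbon. The two measured steps at this position were modest and large, and neither involved a ring, so the change is not directly anticipated. A modest move toward a higher number is expected, a 3.8-fold higher number from compound 2 to compound 4 (0.58 log units; beyond the scatter). Compound 4 is therefore estimated at 8 nM, within 1.5 nM to 40 nM.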

Compound 4, half-maximal inhibitory concentration: 10 nM
The estimate for compound 4 lay 1.3-fold (0.10 log units) below the measured number; measured number inside the range.
By their numbers in this assay, from the lowest: compound 2; then compounds 4 and 3 (each within the scatter of the next); then compound 1.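

A ring is accepted at this position: in this assay cyclopentyl, the only ring tried here, sits level with difluoromethyl (a 1.4-fold lower number from compound 3 to compound 4 (0.15 log units; within the scatter)) and well ahead of methoxymethyl (an 8.8-fold lower number from compound 1 to compound 4 (0.94 log units; beyond the scatter)). Even so, it does not match 2-fluoroethyl (a 4.8-fold higher number from compound 2 to compound 4 (0.68 log units; beyond the scatter)), so the larger all-carbon group gives back part of what that chain achieves. Nothing measured here explains these differences. Still open, going by these compounds, is whether cyclopropyl, cyclohexyl or a cyclopentyl ring carrying fluorine would reach the level of compound 2, and whether a longer chain such as 3-fluoropropyl would do so.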